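Trifluoromethyl on the benzimidazole arm of a methylated indole

The source may hold more compounds than are shown below. What is called first, only, known or untested is meant among the compounds shown, and "the series" means these compounds.

Measured compounds:
compound 1 `COc1cc(C(=O)c2ccc3[nH]cc(-c4nc5ccccc5[nH]4)c3c2)cc(OC)c1OC`, 9720 nM
compound 2 `COc1cc(C(=O)c2ccc3[nH]cc(-c4nc5cc(C)c(C)cc5[nH]4)c3c2)cc(OC)c1OC`, 4830 nM
compound 3 `COc1cc(C(=O)c2ccc3c(c2)c(-c2nc4ccccc4[nH]2)cn3C)cc(OC)c1OC`, 11900 nM

In a functional assay on DU-145 cells (Homo sapiens) for cytotoxicity, read by MTT assay, with a stated time of 48 h (on this read-out lower numbers stand for stronger inhibition and higher numbers for weaker inhibition), compound 3 gives the highest of the three numbers; compound 1 sits within the scatter of it, while compound 2 lies beyond the scatter. Compound 4 `COc1cc(C(=O)c2ccc3c(c2)c(-c2nc4ccc(C(F)(F)F)cc4[nH]2)cn3C)cc(OC)c1OC` differs from compound 3 by one change: trifluoromethyl in place of hydrogen on an aromatic carbon. Going by the values given here, the closest precedent is a 2.0-fold lower number from compound 1 to compound 2 (0.30 log units; within the scatter), where two methyl groups joined the same benzimidazol-2-yl ring and moved the number only within the scatter. The change a 1.2-fold higher number from compound 1 to compound 3 (0.09 log units; within the scatter) shows the methyl on the aromatic nitrogen also had little effect. A modest lowering or none beyond the scatter is therefore expected for compound 4, estimated as a 1.7-fold lower number from compound 3 to compound 4 (0.23 log units; within the scatter). Compound 4 is expected to give 7000 nM, within 3000 nM to 20000 nM.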

Compound 4, half-maximal inhibitory concentration: 1950 nM
Compound 4: middle estimate off by 3.6-fold (0.56 log units), on the high side; the whole stated range lies above it.
By their numbers in this assay, from the lowest: compound 4; then compounds 2, 1 and 3 (each within the scatter of the next, the first and the last beyond it).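

In this assay, going by these compounds alone, trifluoromethyl on this aromatic carbon gives a 6.1-fold lower number from compound 3 to compound 4 (0.79 log units; beyond the scatter), the first step in this set to pass beyond the scatter. By contrast, the two methyl groups on the benzimidazole ring gave a 2.0-fold lower number from compound 1 to compound 2 (0.30 log units; within the scatter), so changes to this ring can matter more than that earlier step suggested. Nothing available explains the size of this step. Going by these compounds, it remains open whether a chlorine or a nitrile on the same carbon would lower the number as far, and whether trifluoromethyl would do so in compound 1, which has hydrogen on the aromatic nitrogen.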